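The compounds below may be only part of what the source reports. "The series", "measured", "known", "first", "only" and "open" are said of these compounds alone.

Measured in a functional assay on C6 cells (Rattus norvegicus) for inhibition, read by sulforhodamine B assay, with a stated time of 72 h; a lower number here means that less compound is needed, a higher number that more compound is needed for the effect:

- Compound 1 `CC(C)(C)c1ccc(C(=O)/C=C/c2ccc([N+](=O)[O-])o2)cc1`: 28600 nM
- Compound 2 `O=C(/C=C/c1ccc([N+](=O)[O-])o1)c1ccc(-c2ccccc2)cc1`: 17700 nM

Within the data shown here, compound 2 stands within the scatter of compound 1, the only other compound measured so far. Compound 3 `O=C(/C=C/c1ccc([N+](=O)[O-])o1)c1ccc(N2CCCCC2)cc1` differs from compound 2 at a single place: piperidin-1-yl in place of phenyl on an aromatic carbon. In words, this is piperidin-1-yl in place of phenyl on an aromatic carbon, para to a large group.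

Among the measured compounds shown here, one measured step bears on this change, since it concerns the same place. Exchanging tert-butyl for phenyl gave a 1.6-fold lower number from compound 1 to compound 2 (0.21 log units; within the scatter), so these two groups leave the number in this assay within the scatter. This is thin evidence. It rests on a single pair, and neither measured compound has a non-aromatic ring with 1 hetero atom at this place. No step beyond the scatter is therefore expected, in either direction, though the range must stay wide.

The expected change is a 1.1-fold lower number from compound 2 to compound 3 (0.04 log units; within the scatter). For compound 3 the estimated value is 16000 nM, with an expected range from 6000 nM to 40000 nM.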

Compound 3, half-maximal effective concentration: 48700 nM
Compound 3: middle estimate off by 3.0-fold (0.48 log units), on the low side, and the stated range ends below it.
By their numbers in this assay, from the lowest: compounds 2, 1 and 3 (each within the scatter of the next, the first and the last beyond it).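

In this assay, the aromatic carbon para to a large group now shows a step beyond the scatter, as piperidin-1-yl in place of phenyl gives a 2.8-fold higher number from compound 2 to compound 3 (0.44 log units; beyond the scatter) and marks a modest difference between these two groups. The same group in place of tert-butyl gives a 1.7-fold higher number from compound 1 to compound 3 (0.23 log units; within the scatter) in the same assay, so among the three groups only phenyl and piperidin-1-yl are separated beyond the scatter, even though both are six-membered rings with the same heavy-atom count. No measurement available here ties this step to any particular property of the groups.

The exchange changes several things at once, replacing an aromatic carbon ring with a non-aromatic ring that carries a nitrogen, so the three compounds cannot show which of these differences goes with the step. Cyclohexyl at this place would keep the non-aromatic ring without the nitrogen, while dimethylamino would keep the nitrogen without the ring, and the compounds shown leave both comparisons open.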